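This account rests on a few compounds, and the source may have more. Where it says the series, first, only, none or still open, it means among the compounds named here.

In an ADME assay on microsomes from liver (Rattus norvegicus) for metabolic stability (on this read-out higher numbers stand for a longer-lived compound and lower numbers for a shorter-lived compound), compound 2, `Nc1nc(NCCNc2ncc(-c3ncc[nH]3)c(-c3cc(F)c(F)cc3F)n2)ccc1[N+](=O)[O-]`, gives > 0.5 h, which is a limit of the assay rather than a measured number. Compound 1, `Nc1nc(NCCNc2ncc(-c3ncc[nH]3)c(-c3cc(F)ccc3F)n2)ccc1[N+](=O)[O-]`, gives > 0.5 h, again a limit. Compound 3, `Nc1nc(NCCNc2ncc(-c3ncc[nH]3)c(-c3ccc(F)cc3Cl)n2)ccc1[N+](=O)[O-]`, gives > 0.5 h, also a limit. Because all three values sit at the limit of > 0.5 h in this assay, at which 3 of the 3 values shown sit, none of the steps between them can be sized: a step that the two limits leave unreadable from compound 1 to compound 2, a step that the two limits leave unreadable from compound 1 to compound 3 and a step that the two limits leave unreadable from compound 2 to compound 3 are all unreadable. What these three compounds do show is that three different halogen patterns on the phenyl ring attached to the shared core have all kept the half-life beyond the limit, without revealing how far beyond.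

Compound 4, `Cc1ccc(-c2nc(NCCNc3ccc([N+](=O)[O-])c(N)n3)ncc2-c2ncc[nH]2)c(Br)c1`, has not yet been measured in this assay. It differs from compound 2 in one place: 2-bromo-4-methylphenyl in place of 2,4,5-trifluorophenyl on an aromatic carbon. The three measured steps bear on this change, since each also swaps the substitution of that same phenyl ring on that same aromatic carbon, yet each was hidden by the limit, so no size or direction can be read from them. Compound 4 is therefore estimated to give 1 h, within a range from 0.4 h to 3 h, and most probably the assay will again report only a limit. The step that this estimate means, a step that the limit leaves unreadable from compound 2 to compound 4, is expected to stay within the usual scatter.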

Compound 4, half-life: > 0.5 h
Compound 4 gave a limit, no number (the forecaster's own chance of this, stated with the estimate: 70%); the middle value does not contradict the limit.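

In this assay compound 4 gives > 0.5 h, which is a limit of the assay and not a number. The steps from compound 1, compound 2 and compound 3 to compound 4 cannot be read, because all four compounds share one limit: the limit of > 0.5 h in this assay, at which 4 of the 4 values shown sit.

The compounds shown leave open how long each half-life actually is, and whether changing the substituted phenyl ring alters it at all.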